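Swapping Fluoro for Methoxymethoxy in a Cytotoxicity Series

The source may report more compounds than this note shows. Statements on the series, on what has been measured and on what is new or still open speak of the compounds shown alone.

For the measured compounds named here, compound 1 `NC(=S)N/N=C/c1ccc(F)c2ccccc12` is one of two compounds so far tested in a toxicity assay on MRC5 cells (Homo sapiens) for cytotoxicity, read by MTT assay, with a stated time of 72 h; on this read-out lower numbers stand for an effect already at smaller amounts and higher numbers for an effect only at larger amounts of compound. In this assay compound 1 reaches only a limit of the assay, > 200000 nM. Compound 2 `CN(C)c1ccc(/C=N/N=C(/N)S)c2ccccc12` likewise shows only a limit in this assay, > 200000 nM. Both values therefore sit at the limit of > 200000 nM in this assay, at which 2 of the 2 values shown sit. Compound 3 `COCOc1ccc(/C=N/NC(N)=S)c2ccccc12` has not yet been tested; it differs from compound 1 by methoxymethoxy in place of fluoro on an aromatic carbon. Going by the values given here, no measured step resembles this change, so no shift beyond the scatter is expected. Compound 3 is expected to give about 200000 nM, within a range from 60000 nM to 400000 nM. The expected step is a number no higher from compound 1 to compound 3 (the limit leaves the size open).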

Compound 3, half-maximal effective concentration: 126000 nM
Estimate against measurement, compound 3: 1.6-fold (0.20 log units) above; low and high end bracket the measured number.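

For the compounds shown here, compound 3 is the only compound so far in this assay to give a number rather than a limit, so with methoxymethoxy on this aromatic carbon the read-out falls within the measurable range. Methoxymethoxy in place of fluoro gives an at least 1.5-fold lower number from compound 1 to compound 3 (0.20 log units; that floor lies within the scatter). Only a floor can be stated for this step, as the value of compound 1 is a limit: the limit of > 200000 nM in this assay, at which 2 of the 3 values shown sit.

With a single number in the series, no trend across groups at this position can be read. Going by these compounds, how an amine, a carboxylic acid or a longer chain on the same aromatic carbon would read remains open.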